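A few compounds are considered here, and "the series" means these few. Any claim that something is new, unique, unknown or untested is made for them only; others in the source may bear on it.

Three compounds of the series have entries in an ADME assay on Vero cells (Chlorocebus sabaeus) for cytotoxicity, read by MTT assay, with a stated time of 72 h; on this read-out lower numbers stand for higher toxicity in this test and higher numbers for lower toxicity in this test. Compound 1 `C[C@]1(CN2CCc3nc(N4CCC(F)(F)CC4)ccc3C2)Cn2cc([N+](=O)[O-])nc2O1` carries no result there: for compound 1 the entry reads "not determined" (no result reported). Compound 2 `C[C@]1(CN2CCc3nc(-c4ccccc4F)ccc3C2)Cn2cc([N+](=O)[O-])nc2O1` reaches only a limit of the assay, giving > 32 ug/mL. Compound 3 `C[C@]1(CN2CCc3nc(-c4cccc(F)c4F)ccc3C2)Cn2cc([N+](=O)[O-])nc2O1` likewise stops at a limit of the assay, giving > 32 ug/mL. The step from compound 2 to compound 3, a step that the two limits leave unreadable from compound 2 to compound 3, cannot be read in size, since both ends sit at the limit of > 32 ug/mL in this assay, at which 2 of the 3 values shown sit. Compound 3 thus stands at the limit, with one other compound at the same limit and one compound without a number.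

Compound 4 `C[C@]1(CN2CCc3nc(-c4cccc(Cl)c4F)ccc3C2)Cn2cc([N+](=O)[O-])nc2O1` differs from compound 3 by chloro in place of fluoro on an aromatic carbon. Within the data shown here, no measured step shows this exchange. Among the measured compounds shown here, the only measured step, a step that the two limits leave unreadable from compound 2 to compound 3, has both of its ends at a limit, so it yields no size in either direction, and the scatter cannot be placed against it. The expectation for compound 4 in this assay therefore rests on the limit alone: compound 4 is expected to remain at the limit. The expected step is a step that the limit leaves unreadable from compound 3 to compound 4. The estimate for compound 4 is 40 ug/mL, within 20 ug/mL to 100 ug/mL.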

Compound 4, half-maximal cytotoxic concentration: > 32 ug/mL
Compound 4 gave a limit, no number; the forecaster's own chance of this, stated with the estimate: 85%; the middle value does not contradict the limit.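

Compound 2, compound 3 and compound 4 all end at a limit in this assay, so no step among them can be read in size: the limit of > 32 ug/mL in this assay, at which 3 of the 4 values shown sit.

The compounds shown leave open whether hydrogen, fluoro or chloro at this place on the aromatic ring makes any difference in this assay beyond that limit.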